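The source may hold more compounds than are shown below. What is called first, only, known or untested is meant among the compounds shown, and "the series" means these compounds.

Measured so far in a functional assay on BJAB cells (Homo sapiens) for antiproliferative activity, with a stated time of 4 days; a lower number here means that less compound is needed, a higher number that more compound is needed for the effect:
- Compound 1 `Cc1ccccc1-c1c(C)nn(-c2nc(-c3ccc(Cl)c(Cl)c3)c(SC(C)C)s2)c1C(=O)O` gives 5500 nM
- Compound 2 `CC(=O)Nc1ccc(-c2c(C)nn(-c3nc(-c4ccc(Cl)c(Cl)c4)c(SC(C)C)s3)c2C(=O)O)cc1` gives 139000 nM
- Compound 3 `Cc1cc(-c2c(C)nn(-c3nc(-c4ccc(Cl)c(Cl)c4)c(SC(C)C)s3)c2C(=O)O)cc(C)n1` gives 580 nM

Compound 3 stands lowest of the three numbers in this assay, so the least of it is needed for the effect. Its nearest neighbour is compound 1, with a 9.5-fold lower number from compound 1 to compound 3 (0.98 log units; beyond the scatter) read in reverse; compound 2 lies furthest away, as a 240-fold lower number from compound 2 to compound 3 (2.38 log units; beyond the scatter) shows.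

Compound 4 `Cc1nn(-c2nc(-c3ccc(Cl)c(Cl)c3)c(SC(C)C)s2)c(C(=O)O)c1-c1cncc(C#N)c1` differs from compound 3 at one spot: 5-cyanopyridin-3-yl in place of 2,6-dimethylpyridin-4-yl on an aromatic carbon. The ring that changes hands stays a six-membered aromatic ring with one hetero atom, but the two methyl groups of compound 3 are gone and a nitrile arrives.

Both measured steps bear on this position, since each of them swaps the same group on the same aromatic carbon. a 9.5-fold lower number from compound 1 to compound 3 (0.98 log units; beyond the scatter) is modest, while a 240-fold lower number from compound 2 to compound 3 (2.38 log units; beyond the scatter) and a 25-fold higher number from compound 1 to compound 2 (1.40 log units; beyond the scatter) are large. All three agree that this spot is sensitive, and compound 3 holds the lowest number of the set. Among the measured compounds shown here, no measured pair tells how a nitrile on this ring behaves. A step beyond the scatter seems likely, most plausibly toward a higher number, and the expected size is a 3.4-fold higher number from compound 3 to compound 4 (0.54 log units; beyond the scatter). Compound 4 is therefore estimated at 2000 nM, within a range from 500 nM to 8000 nM.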

Compound 4, half-maximal effective concentration: 20000 nM
Estimate against measurement, compound 4: 10-fold (1.00 log units) below; measured number outside the range, above it.
By their numbers in this assay, from the lowest: compound 3; then compound 1; then compound 4; then compound 2.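

In this assay, the ring type alone does not secure a low number: both groups are six-membered aromatic rings with one hetero atom, yet the swap gives a 34-fold higher number from compound 3 to compound 4 (1.54 log units; beyond the scatter), a large step. So the low number of compound 3 depends on more than the ring type, and the 5-cyanopyridin-3-yl group does not share the advantage of the 2,6-dimethylpyridin-4-yl group over the two benzene-based groups, with a 3.6-fold higher number from compound 1 to compound 4 (0.56 log units; beyond the scatter) against the 2-methylphenyl group, while a 7.0-fold lower number from compound 2 to compound 4 (0.84 log units; beyond the scatter) still places it on the better side of the 4-acetamidophenyl group. Nothing measured beyond these cell numbers is available to explain this order.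

The compounds shown leave open which part of the change counts: the loss of the two methyl groups, the arrival of the nitrile, or the different attachment of the ring, since all three happen in a single step. They also leave open how the 5-cyanopyridin-3-yl ring would behave with an amine or a methoxy group in place of the nitrile.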